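Swapping the para substituent: from ethoxycarbonyl to iodo

The source may hold more compounds than are shown below. What is called first, only, known or untested is meant among the compounds shown, and "the series" means these compounds.

The series rests on a shared core, seen in compound 1 `CCCCc1ccc(NC(=O)N[C@H](C)c2ccccc2)cc1` and compound 2 `CCOC(=O)c1ccc(NC(=O)N[C@H](C)c2ccccc2)cc1`, which differ only in the group on one aromatic carbon. Among the compounds with values here, in an ADME assay on the whole organism with Oryza sativa as the target, tested at 10 uM (a lower number here means a stronger effect, a higher number a weaker effect of the compound at the concentration tested), compound 1 gives 28%, while compound 2 gives 92%, the highest of the two numbers known. Within the data shown here, the single measured step, a number 64 percentage points higher from compound 1 to compound 2 (beyond the scatter), shows how much this position can move the read-out.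

Compound 3 `C[C@@H](NC(=O)Nc1ccc(I)cc1)c1ccccc1` is not yet measured. Its change from compound 2 is iodo in place of ethoxycarbonyl on an aromatic carbon. Among the measured compounds shown here, the one step that bears on it is a number 64 percentage points higher from compound 1 to compound 2 (beyond the scatter), since it too concerns the group on that same aromatic carbon; but that step removed butyl and brought in ethoxycarbonyl, whereas here ethoxycarbonyl leaves and iodo enters, so it speaks only to the range the position can span. The author therefore expects a step of a number 42 percentage points lower from compound 2 to compound 3 (beyond the scatter) in this assay, downward from compound 2, of moderate size rather than none at all. The estimate for compound 3 in this assay is 50%, with a range from 20% to 85%.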

Compound 3, a percentage reported as activity, at one concentration (the size of the read-out at that concentration, not a potency): 85%
Beside the measured number, compound 3's estimate is 35 percentage points below it, within the range that was stated.
By their numbers in this assay, from the lowest: compound 1; then compounds 3 and 2 (each within the scatter of the next).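

In this assay, iodo in place of ethoxycarbonyl on the aromatic carbon gives a number 7 percentage points lower from compound 2 to compound 3 (within the scatter), so at this position a group of one heavy atom with no hydrogen-bond acceptors and a group of five heavy atoms with two hydrogen-bond acceptors cannot be told apart, which the first pair alone could not show. Iodo in place of butyl on the same carbon gives a number 57 percentage points higher from compound 1 to compound 3 (beyond the scatter), so the large step seen earlier is not tied to ethoxycarbonyl alone, and among the three compounds shown it is butyl that stands apart from the other two groups. Nothing available gives a reason for either of these results.

As far as these compounds go, it remains open whether a shorter chain such as ethyl, or a longer chain such as hexyl, would stay close to compound 1, and so whether the chain itself sets the low number. From the compounds shown here alone, it is equally open whether a carboxylic acid, an amine, or another halogen such as chloro on that carbon would fall with compound 2 and compound 3 or with compound 1.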